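This account rests on a few compounds, and the source may have more. Where it says the series, first, only, none or still open, it means among the compounds named here.

Three compounds share one core and differ only in the group carried on one aromatic carbon. Compound 1 `Cc1cccc(C)c1OC(C)C1=NCCN1` carries two methyl groups and in an assay on CHO cells with Alpha-2C adrenergic receptor (Homo sapiens) as the target (on this read-out lower numbers stand for smaller maximal responses and higher numbers for larger maximal responses), compound 1 gives 0.82. Compound 2 `CC(Oc1ccccc1Br)C1=NCCN1` carries a bromo group, and in this assay compound 2 gives 0.87. Compound 3 `CCc1ccccc1OC(C)C1=NCCN1` carries an ethyl group, and in this assay compound 3 gives 0.6.

Among these three numbers compound 2 stands highest, but its gap to compound 1 lies within the scatter, so the two cannot be ordered. Going by the values given here, only one measured step separates compound 2 from another compound by a single change: a number 0.27 lower from compound 2 to compound 3 (beyond the scatter).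

Compound 4 `C=C(C)c1ccccc1OC(C)C1=NCCN1` is not yet measured. Compared with compound 2 it differs as follows: 1-methylethenyl in place of bromo on an aromatic carbon. Among the compounds with values here, this change resembles the one from compound 2 to compound 3, where a small carbon group replaced the bromo group and the response fell by a modest amount beyond the scatter. On that single comparison a drop of similar size is expected here, though one step gives only a rough guide. Compound 4 is therefore estimated at 0.65, within a range from 0.45 to 0.85, which would mean an expected step of a number 0.22 lower from compound 2 to compound 4 (beyond the scatter).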

Compound 4, intrinsic activity: the largest response reached, as a fraction of the reference agonist's: 0.71
For compound 4 the middle estimate is 0.060 below the measured one; the measured number falls inside the stated range.
By their numbers in this assay, from the lowest: compound 3; then compound 4; then compounds 1 and 2 (each within the scatter of the next).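

In this assay, a second carbon group at this aromatic carbon also falls short of bromo, with a number 0.16 lower from compound 2 to compound 4 (beyond the scatter) as the measured change, so the fall seen with ethyl is not a lone case among the three compounds that differ only here. The carbon groups are not interchangeable either: a number 0.11 higher from compound 3 to compound 4 (beyond the scatter) is a step beyond the scatter, which shows that the maximal response also shifts from one carbon group to another, and it places 1-methylethenyl between ethyl and bromo on this read-out. None of the available information bears on why the three groups fall in this order.

The step from ethyl to 1-methylethenyl changes two things at once, the carbon count and the presence of a double bond, and the compounds shown cannot separate them; 1-methylethyl, with three carbons and no double bond, would be the direct test. Also open, as far as these compounds go, is how this position responds to groups containing atoms other than carbon or bromine, such as an amine or a methoxy group, and to a longer chain such as butyl.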